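Ester of an indolyl biphenyl amide acid: cytotoxicity check

The compounds below may be only part of what the source reports. "The series", "measured", "known", "first", "only" and "open" are said of these compounds alone.

Measured so far in an ADME assay on Raji cells (Homo sapiens) for cytotoxicity, read by CellTiter-Glo and resazurin assay, with a stated time of 72 h; on this read-out higher numbers stand for an effect only at larger amounts of compound and lower numbers for an effect already at smaller amounts:
compound 1 `CC(C)N(Cc1cccc(OCCCCCC(=O)O)c1)C(=O)c1ccc(-c2ccc3[nH]ccc3c2)cc1`: > 26000 nM, a limit of the assay
compound 2 `CC(C)N(Cc1cccc(OCCCCCC(=O)O)c1)C(=O)c1ccc(-c2ccc3cc[nH]c3c2)cc1`: > 26000 nM, a limit of the assay
compound 3 `CC(C)N(Cc1cccc(OCCCCCC(=O)O)c1)C(=O)c1ccc(-c2cccc(C(F)(F)F)c2)cc1`: > 26000 nM, a limit of the assay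

Compound 1 stands at the limit of > 26000 nM in this assay, at which 3 of the 3 values shown sit; no number is known for it, only the limit. The same holds for compound 2 and compound 3, so the steps a step that the two limits leave unreadable from compound 1 to compound 2, a step that the two limits leave unreadable from compound 1 to compound 3 and a step that the two limits leave unreadable from compound 2 to compound 3 are all unreadable in size and direction. Nothing in the measured set distinguishes an indolyl from a 3-(trifluoromethyl)phenyl at the aromatic carbon within this assay.

Compound 4 `CCOC(=O)CCCCCOc1cccc(CN(C(=O)c2ccc(-c3ccc4[nH]ccc4c3)cc2)C(C)C)c1` is the ethyl ester of compound 1, the change being (ethyl in place of hydrogen on an oxygen next to a carbonyl group). For the measured compounds named here, no measured step touches this position; the only bearing on it is that every compound of the shared core, whatever the aromatic substituent, sits at the limit (the limit of > 26000 nM in this assay, at which 3 of the 3 values shown sit). From that the expected step that the limit leaves unreadable from compound 1 to compound 4 is none beyond the scatter, with the most likely result again a limit rather than a number. Compound 4 is therefore estimated at 30000 nM, in the range 10000 nM to 90000 nM, to be confirmed once the measurement is in hand.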

Compound 4, half-maximal effective concentration: > 26000 nM
Compound 4 ended at the assay's limit; the forecaster's own chance of this, stated with the estimate: 70%; the middle value is on the limit's open side.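

No step can be read from compound 1 to compound 4 in this assay, since each of the two gives only a limit and not a number, as do compound 2 and compound 3: the limit of > 26000 nM in this assay, at which 4 of the 4 values shown sit.

Still open, on these data alone, is where any of these four compounds would give an actual number, and whether ethyl in place of hydrogen shifts it in either direction.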